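The compounds below may be only part of what the source reports. "The series", "measured", "known", "first", "only" and "open" are said of these compounds alone.

Measured compounds in a functional assay on the whole organism (strain albino) for inhibition, with Rattus norvegicus as the target, read by paw edema, with a stated time of 1 h, at a dose of 0.28 mmol/kg by the oral route; on this read-out higher numbers stand for more inhibition at the one dose given (going by the name of the read-out) and lower numbers for less inhibition:
Compound 1 `CCn1c(SCC(=O)c2ccccc2)nnc1-c1ccc(OC)cc1` gives 53%.
Compound 2 `C=CCn1c(SCC(=O)c2ccccc2)nnc1-c1ccc(OC)cc1` gives 49%.
Compound 3 `CCn1c(SC/C(=N/O)c2ccccc2)nnc1-c1cc(OC)c(OC)c(OC)c1` gives 63%.

Compounds 1 and 2 share a core and differ only in one place: vinyl in place of methyl on a saturated chain carbon bound to an aromatic nitrogen. That change made a step of a number 4 percentage points lower from compound 1 to compound 2 (within the scatter) in this assay. Compound 3 carries a different core, and the difference between the two cores is not broken down here. Compound 3 has the highest of the three numbers, but its gap to compound 1 stays within the scatter, while its gap to compound 2 lies beyond it.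

Compound 4 `C=CCn1c(SC/C(=N/O)c2ccccc2)nnc1-c1cc(OC)c(OC)c(OC)c1` has not yet been measured in this assay. Among the compounds with values here, it differs from compound 3 by vinyl in place of methyl on a saturated chain carbon bound to an aromatic nitrogen, the same change, in the same place, as the one made from compound 1 to compound 2. Since that earlier step was a number 4 percentage points lower from compound 1 to compound 2 (within the scatter), the step for compound 4 is expected to be small as well, about a number 4 percentage points lower from compound 3 to compound 4 (within the scatter). Compound 4 is therefore estimated at 59%, with an expected range from 46% to 72%.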

Compound 4, a percentage reported as inhibition, in the whole organism at one dose (the size of the read-out at that dose, not a potency): 61%
Estimate against measurement, compound 4: 2 percentage points below; the measured number falls inside the stated range.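

On the core of compound 3, the change of methyl to vinyl on a saturated chain carbon bound to an aromatic nitrogen, which also reads as ethyl to allyl, gave in this assay a step of a number 2 percentage points lower from compound 3 to compound 4 (within the scatter). Set beside the step on the core of compound 1, the change shows no difference between the two cores: the same change on two cores in this assay, a number 4 percentage points lower (within the scatter) from compound 1 to compound 2 and a number 2 percentage points lower (within the scatter) from compound 3 to compound 4, 2 percentage points apart, within the scatter of two such steps. Within the data shown here, this shows only that the change left the reading within the scatter on these two cores at the one dose given, and two pairs neither set a rule for other cores nor say anything about potency.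

The compounds shown leave open how a longer chain such as butyl, or a chain ending in an amine or a carboxylic acid, would read in place of the ethyl or allyl. They also leave open how much each part of the difference between the two cores contributes to the reading.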